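From Methoxy to Methylsulfanyl at One Aromatic Carbon

The source may report more compounds than this note shows. Statements on the series, on what has been measured and on what is new or still open speak of the compounds shown alone.

Of the compounds shown here, three sharing one core have been measured in a functional assay on DU-145 cells (Homo sapiens) for inhibition, read by trypan blue exclusion, with a stated time of 96 h; on this read-out higher numbers stand for weaker inhibition of growth and lower numbers for stronger inhibition of growth. Compound 1 (`O=C(O)c1ccc(/C=C(/SCc2ccc(Cl)cc2)C(=O)c2ccc(C(=O)O)cc2)cc1`) gives > 100000 nM, which is a limit of the assay and not a number. Compound 2 (`CN(C)c1ccc(/C=C(/SCc2ccc(Cl)cc2)C(=O)c2ccc(C(=O)O)cc2)cc1`) gives 1000 nM, and compound 3 (`COc1ccc(/C=C(/SCc2ccc(Cl)cc2)C(=O)c2ccc(C(=O)O)cc2)cc1`) gives 10000 nM, the higher of the two actual numbers. The next compound, compound 4 (`CSc1ccc(/C=C(/SCc2ccc(Cl)cc2)C(=O)c2ccc(C(=O)O)cc2)cc1`), has not yet been measured and differs from compound 3 by one substitution: methylsulfanyl in place of methoxy on an aromatic carbon. Methylsulfanyl stands in place of methoxy on an aromatic carbon, para to a large group.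

Three measured steps involve changes on this same carbon. The step of an at least 100-fold lower number from compound 1 to compound 2 (2.00 log units; beyond the scatter) is large, the step of an at least 10-fold lower number from compound 1 to compound 3 (1.00 log units; beyond the scatter) is at least modest, and the step of a 10-fold higher number from compound 2 to compound 3 (1.00 log units; beyond the scatter) is modest. None of them tests methylsulfanyl directly, so they show only that this carbon can move the read-out. The two groups have matching counts, and no step beyond the scatter is expected in this assay, with only a slight lean towards a lower number. The estimated change is a 1.7-fold lower number from compound 3 to compound 4 (0.22 log units; within the scatter). For compound 4 the expected value is 6000 nM, within an estimated range of 1500 nM to 25000 nM.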

Compound 4, concentration for 50% growth inhibition: > 100000 nM
Compound 4: no number, only a limit (the forecaster's own chance of this, stated with the estimate: 10%); at least 16-fold (1.22 log units) between middle value and limit.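

In this assay compound 4 gives > 100000 nM, which is a limit of the assay and not a number. Exchanging only the oxygen of methoxy for the sulfur of methylsulfanyl, a change that leaves the heavy-atom, donor and acceptor counts as they were, produces an at least 10-fold higher number from compound 3 to compound 4 (1.00 log units; beyond the scatter), and the comparison with the dimethylamino compound gives an at least 100-fold higher number from compound 2 to compound 4 (2.00 log units; beyond the scatter). The earlier compounds showed that this carbon could move the read-out, whereas this result shows that it also separates two groups of matching counts, so those counts do not predict growth inhibition here; the step from compound 1 to compound 4 cannot be read, as both compounds sit at the same limit: the limit of > 100000 nM in this assay, at which 2 of the 4 values shown sit.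

From the compounds shown here alone, how far compound 4 lies past that limit stays open, so the true size of both new steps is unknown. Equally open, going by these compounds, is whether a longer chain on the sulfur, such as ethylsulfanyl, or a free amine on this aromatic carbon would side with compound 4 or with compound 2.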